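Swapping Sulfamoyl for Ethyl on a Benzimidazole-like Core

The source may report more compounds than this note shows. Statements on the series, on what has been measured and on what is new or still open speak of the compounds shown alone.

Antagonist potency here is read in a functional assay for antagonist activity at Neuropeptides B/W receptor type 1 (Homo sapiens), read by cAMP accumulation; on this read-out higher numbers stand for weaker inhibition and lower numbers for stronger inhibition. Compound 2, `NS(=O)(=O)c1ccc(-c2nc3cc([N+](=O)[O-])ccc3[nH]2)cc1`, gives > 31600 nM in this assay, which is a limit of the measurement rather than a number. Compound 2 therefore stands at the upper edge of what the assay can report, together with most of the set: the limit of > 31600 nM in this assay, at which 2 of the 3 values shown sit. Compound 1, `O=[N+]([O-])c1ccc2[nH]c(-c3ccc(Cl)c(Br)c3)nc2c1`, also reaches only a limit, > 31600 nM, in this assay. Compound 3, `FC(F)(F)c1ccc2[nH]c(-c3ccc(-c4nnc[nH]4)cc3)nc2c1`, which carries a different group on the shared core and a different ring on the outer aromatic ring, gives 3080 nM in this assay, a measurable value.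

Compound 4, `CCc1ccc(-c2nc3cc([N+](=O)[O-])ccc3[nH]2)cc1`, differs from compound 2 in one place: ethyl in place of sulfamoyl on an aromatic carbon. Among the compounds with values here, no pair of measured compounds shows this exchange, so its effect cannot be read off the data. Since the two compounds sharing the nitro-bearing core both sit at the limit, the expected step from compound 2 to compound 4 is an at least 1.5-fold lower number from compound 2 to compound 4 (0.19 log units; that floor lies within the scatter), a small gain at best, within or barely beyond the scatter. The estimated value for compound 4 in this assay is 20000 nM, with a range from 5000 nM to 40000 nM.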

Compound 4, half-maximal inhibitory concentration: 1020 nM
Estimate against measurement, compound 4: 20-fold (1.29 log units) above; measured number below the stated range.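

In this assay, ethyl in place of sulfamoyl on this aromatic carbon, para to a large group, gives an at least 30-fold lower number from compound 2 to compound 4 (1.49 log units; beyond the scatter), a large step and the first one in this set that can be read at this position. Until now the shared core of compound 2 had shown no measurable value, and compound 4 shows that this core can give one when only this group is changed. The step has a floor but no known top, since compound 2 reaches only a limit, which is not a number, so the real gap may be wider than the one printed: the limit of > 31600 nM in this assay, at which 2 of the 4 values shown sit.

As far as these compounds go, with only sulfamoyl and ethyl at this position, it stays open whether a longer chain such as propyl, a smaller methyl or a polar group such as an amine or a carboxylic acid would give a lower or a higher number than ethyl. The exchange also changes several things at once, removing a hydrogen-bond donor and acceptors and altering the heavy-atom count, and these two compounds cannot show which of those changes matters.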